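The source may hold more compounds than are shown below. What is called first, only, known or untested is meant among the compounds shown, and "the series" means these compounds.

In an ADME assay on Vero cells (Chlorocebus sabaeus) for cytotoxicity, read by resazurin assay, with a stated time of 72 h (on this read-out higher numbers stand for weaker inhibition and lower numbers for stronger inhibition), compound 1 `COc1ccc(C(=O)CCN2CCN(c3ccc([N+](=O)[O-])cc3)CC2)cc1` gives 587000 nM and compound 2 `O=C(CCN1CCN(c2ccc([N+](=O)[O-])cc2)CC1)c1ccc(F)cc1` gives 111000 nM. Compound 3 `O=C(CCN1CCN(c2ccc(C(F)(F)F)cc2)CC1)c1ccc(Br)cc1` gives 78800 nM, the lowest of the three numbers, although this lies within the scatter of compound 2 and beyond it only against compound 1.

Compound 4 `O=C(CCN1CCN(c2ccc([N+](=O)[O-])cc2)CC1)c1ccc(Br)cc1` departs from compound 3 by nitro in place of trifluoromethyl on an aromatic carbon. Among the compounds with values here, no measured step makes this exchange. Within the data shown here, the only step available, a 5.3-fold lower number from compound 1 to compound 2 (0.72 log units; beyond the scatter), is modest and swaps fluoro in place of methoxy, so it bears on the change only indirectly, showing how far one substituent swap can move these numbers. Compound 2 carries the nitro group and gives 111000 nM, close to compound 3, but compound 1 also carries it and stands well apart. The data therefore point to no clear shift in this assay, and no step beyond the scatter is expected.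

The estimated step is a 1.2-fold higher number from compound 3 to compound 4 (0.08 log units; within the scatter). Compound 4 is expected at 95000 nM, with an estimated range from 45000 nM to 200000 nM.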

Compound 4, half-maximal inhibitory concentration: 79800 nM
Beside the measured number, compound 4's estimate is 1.2-fold (0.08 log units) above it, and the stated range covers the measured number.
By their numbers in this assay, from the lowest: compounds 3, 4 and 2 (each within the scatter of the next); then compound 1.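

In this assay, the direct exchange on an aromatic carbon para to a large group, with everything else held the same, gives a 1.0-fold higher number from compound 3 to compound 4 (0.01 log units; within the scatter) and so does not tell nitro and trifluoromethyl apart. Where the nitro group is kept, bromo in place of fluoro gives a 1.4-fold lower number from compound 2 to compound 4 (0.14 log units; within the scatter) and leaves those two halogens untold apart as well, whereas bromo in place of methoxy gives a 7.4-fold lower number from compound 1 to compound 4 (0.87 log units; beyond the scatter), so among these exchanges only the one that removes methoxy reaches beyond the scatter. No measurement offered here accounts for these numbers.

As far as these compounds go, whether an amine or a carboxylic acid at this position would move the number beyond the scatter remains open. Also open, from the compounds shown here alone, is whether the nitro and trifluoromethyl groups would stay level with fluoro or methoxy in place of bromo, since they are compared only with bromo present.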